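A few compounds are considered here, and "the series" means these few. Any claim that something is new, unique, unknown or untested is made for them only; others in the source may bear on it.

Measured so far, in a functional assay on MCF7 cells (Homo sapiens) for cytotoxicity, read by CellTiter-Glo, with a stated time of 5 days; on this read-out lower numbers stand for stronger inhibition and higher numbers for weaker inhibition:
- compound 1 `C/C(=C(/c1ccc(/C=C/C(=O)O)cc1)c1ccc2[nH]ncc2c1)c1ccccc1`: 40 nM
- compound 2 `CC/C(=C(/c1ccc(/C=C/C(=O)O)cc1)c1ccc2[nH]ncc2c1)c1ccccc1`: 7.2 nM
- compound 3 `O=C(O)/C=C/c1ccc(/C(=C(/CCCl)c2ccccc2)c2ccc3[nH]ncc3c2)cc1`: 9 nM

The three measured compounds share one core and differ only in the group on the saturated chain carbon bound to the double-bonded chain carbon. Compound 2 carries the lowest of the three numbers, but compound 3 stands close, a 1.3-fold higher number from compound 2 to compound 3 (0.10 log units; within the scatter), so the two cannot be ordered. Compound 1 is the furthest away, a 5.6-fold lower number from compound 1 to compound 2 (0.74 log units; beyond the scatter), and the related step of a 4.4-fold lower number from compound 1 to compound 3 (0.65 log units; beyond the scatter) points the same way.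

Compound 4 `CC/C(=C(/c1ccc(/C=C/C(=O)O)cc1)c1ccc2[nH]nc(F)c2c1)c1ccccc1` differs from compound 2 by fluoro in place of hydrogen on an aromatic carbon. For the measured compounds named here, every measured step concerns the chain, none touches the five-membered aromatic ring of the fused system, so no measured step bears on this change. With nothing in the data pointing up or down, the expectation for compound 4 is a step of no size beyond the scatter, a 1.0-fold higher number from compound 2 to compound 4 (0.02 log units; within the scatter). Compound 4 is therefore estimated at 7.5 nM in this assay, within a range from 3 nM to 20 nM.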

Compound 4, half-maximal inhibitory concentration: 5 nM
The estimate for compound 4 lay 1.5-fold (0.18 log units) above the measured number, within the range that was stated.
By their numbers in this assay, from the lowest: compounds 4, 2 and 3 (each within the scatter of the next); then compound 1.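

For the compounds shown here, until compound 4, every measured change lay on the chain; this is the first to touch the five-membered aromatic ring of the fused system, at the carbon next to the ring nitrogen. In this assay, fluoro in place of hydrogen at this carbon gives a 1.4-fold lower number from compound 2 to compound 4 (0.16 log units; within the scatter) and so shows neither a gain nor a loss that can be told apart from the scatter, which means this carbon can carry a fluoro without a clear change in the number. No measurement at hand explains this result.

Going by these compounds, whether a chloro, a methyl or an amine at the same carbon would leave the number equally unchanged remains open. So does whether the fluoro would behave the same way alongside the shorter chain of compound 1 or the chlorinated chain of compound 3.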